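Imidazole in place of imidazoline on the amide series

The source may report more compounds than this note shows. Statements on the series, on what has been measured and on what is new or still open speak of the compounds shown alone.

Compound 1 `c1ccc(-c2ccno2)c(OCC2=NCCN2)c1` gives 100 nM in a functional assay for activation of Alpha-1D adrenergic receptor (Homo sapiens); a lower number here means that less compound is needed, a higher number that more compound is needed for the effect. Compound 2 `CCN(CC)C(=O)c1ccccc1OCC1=NCCN1` reaches only a limit, < 100000 nM, in this assay. For compound 2 that limit is all that the numbers show (the limit of < 100000 nM in this assay, at which 1 of the 2 values shown sits). Compound 3 `CCN(CC)C(=O)c1ccccc1OCc1c[nH]cn1` differs from compound 2 by a group of 5 heavy atoms (3 carbon, 2 nitrogen; one five-membered aromatic ring with 2 hetero atoms) in place of a group of 5 heavy atoms (3 carbon, 2 nitrogen; one five-membered non-aromatic ring with 2 hetero atoms), on a saturated chain carbon bound to an oxygen on an aromatic ring. For the measured compounds named here, no measured pair covers this change, so the data give no size for it; since the starting point is a limit, the step is expected to be small in this assay, a step that the limit leaves unreadable from compound 2 to compound 3. Compound 3 is expected to give 50000 nM, within 5000 nM to 200000 nM, and may again end at a limit.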

Compound 3, half-maximal effective concentration: < 100000 nM
Compound 3: only a limit was reported (the forecaster's own chance of this, stated with the estimate: 60%); the middle value is on the limit's open side.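

Compound 2 and compound 3 both end at a limit in this assay, so no step between them can be read: the limit of < 100000 nM in this assay, at which 2 of the 3 values shown sit.

Still open, on these data alone, is what size, if any, the change to 1H-imidazol-4-yl has in this assay.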